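From 3-methoxyphenyl to 4-acetylphenyl on the shared core

The source may hold more compounds than are shown below. What is called first, only, known or untested is meant among the compounds shown, and "the series" means these compounds.

In a functional assay on MDA-MB-231 cells (Homo sapiens) for antiproliferative activity, read by MTT assay, with a stated time of 72 h (on this read-out higher numbers stand for weaker inhibition and lower numbers for stronger inhibition), compound 1 (`Cc1ccc(NC(=O)CCc2cccc3c2B(O)OC3)cc1`) gives 1100 nM and compound 2 (`COc1cccc(-c2cccc(NC(=O)CCc3ccc4c(c3)COB4O)c2)c1`) gives 90000 nM as the higher of the two numbers, a gap beyond the scatter. Compound 3 (`CC(=O)c1ccc(-c2cccc(NC(=O)CCc3ccc4c(c3)COB4O)c2)cc1`) carries 4-acetylphenyl in place of 3-methoxyphenyl on an aromatic carbon. For the measured compounds named here, no measured pair shows what this swap does, so the expectation rests only on compound 2 standing at the top of the two numbers. An estimated step of a 3.0-fold lower number from compound 2 to compound 3 (0.48 log units; beyond the scatter) is expected, modest in size and towards a lower number. Compound 3 is expected at 30000 nM within an estimated range of 5000 nM to 100000 nM in this assay.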

Compound 3, half-maximal inhibitory concentration: 66000 nM
Compound 3: middle estimate off by 2.2-fold (0.34 log units), on the low side, and the stated range covers the measured number.
By their numbers in this assay, from the lowest: compound 1; then compounds 3 and 2 (each within the scatter of the next).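

In this assay the exchange of 3-methoxyphenyl for 4-acetylphenyl, on an aromatic carbon meta to a large group, gives a 1.4-fold lower number from compound 2 to compound 3 (0.13 log units; within the scatter) and so no real difference. For the compounds shown here, this is the first measured pair at this position, and it shows that these two substituted phenyl groups cannot be told apart here. No measured evidence offers an explanation for this result.

On these data alone, whether an amine, a carboxylic acid or a longer chain at this position would give a different number remains open.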